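Swapping a Trifluoromethyl Aryl for a Nitro Aryl

The source may hold more compounds than are shown below. What is called first, only, known or untested is meant among the compounds shown, and "the series" means these compounds.

Of the compounds shown here, three built on one shared core have been tested in a functional assay on HeLa cells (Homo sapiens) for antiproliferative activity, with a stated time of 24 h; a higher number here means a weaker inhibitor, a lower number a stronger inhibitor. Compound 1 `NC(=O)c1c(NC(=O)c2ccccc2Cl)sc2c1CCN(C(=S)Nc1cc(C(F)(F)F)cc(C(F)(F)F)c1)C2` gives 48900 nM, compound 2 `NC(=O)c1c(NC(=O)c2ccccc2Br)sc2c1CCN(C(=S)Nc1ccccc1Cl)C2` gives 46900 nM, and compound 3 `NC(=O)c1c(NC(=O)c2ccc(C(F)(F)F)cc2)sc2c1CCN(C(=S)Nc1cc(C(F)(F)F)cc(C(F)(F)F)c1)C2` gives 49000 nM. Compound 3 stands level with compound 1 and compound 2, since its gaps to each lie within the scatter. Compound 4 `NC(=O)c1c(NC(=O)c2cccc([N+](=O)[O-])c2)sc2c1CCN(C(=S)Nc1cc(C(F)(F)F)cc(C(F)(F)F)c1)C2` differs from compound 3 by 3-nitrophenyl in place of 4-(trifluoromethyl)phenyl on a carbonyl carbon. Going by the values given here, the only measured step at this same place, a 1.0-fold higher number from compound 1 to compound 3 (0.00 log units; within the scatter), produced nothing beyond the scatter, and the change there was also an aryl swap on the carbonyl carbon. The expected step is therefore a 1.0-fold lower number from compound 3 to compound 4 (0.01 log units; within the scatter), none beyond the scatter. Compound 4 is accordingly estimated at 48000 nM, with a range from 24000 nM to 96000 nM.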

Compound 4, half-maximal inhibitory concentration: 27200 nM
Estimate against measurement, compound 4: 1.8-fold (0.25 log units) above; the measured number falls inside the stated range.
By their numbers in this assay, from the lowest: compounds 4, 2, 1 and 3 (each within the scatter of the next).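

In this assay, 3-nitrophenyl on the carbonyl carbon gives a 1.8-fold lower number from compound 3 to compound 4 (0.26 log units; within the scatter) and a 1.8-fold lower number from compound 1 to compound 4 (0.25 log units; within the scatter). This group brings in hydrogen-bond acceptors that 4-(trifluoromethyl)phenyl lacks, yet neither step leaves the scatter, so all three aryl groups at this place read alike. No supporting data bear on this result.

Still open, on these data alone, is whether a group of another kind on this carbonyl carbon, such as a longer alkyl chain or a phenyl ring carrying an amine or a carboxylic acid, would move the number beyond the scatter.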